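Side-chain exchange on the shared core

The source may hold more compounds than are shown below. What is called first, only, known or untested is meant among the compounds shown, and "the series" means these compounds.

Among the compounds with values here, in a functional assay on DU-145 cells (Homo sapiens) for cytotoxicity, read by MTT assay (on this read-out higher numbers stand for weaker inhibition and lower numbers for stronger inhibition), compound 1 `CC(C)=CC[C@@H](OCC(C)O)C1=CC(=O)c2c(O)ccc(O)c2C1=O` gives 16100 nM and compound 2 `CCC(CO[C@H](CC=C(C)C)C1=CC(=O)c2c(O)ccc(O)c2C1=O)OC(C)=O` gives 25400 nM, so compound 2 sits within the scatter of the only other measured number. Compound 3 `CC(C)=CC[C@@H](OC(=O)CC(C)(O)C(C)C)C1=CC(=O)c2c(O)ccc(O)c2C1=O` carries a new side chain: (2-hydroxy-2,3-dimethylbutyl)carbonyl in place of 2-acetoxybutyl on an oxygen on a saturated carbon. This places (2-hydroxy-2,3-dimethylbutyl)carbonyl on the oxygen in place of 2-acetoxybutyl. Within the data shown here, the sole measured step, a 1.6-fold higher number from compound 1 to compound 2 (0.20 log units; within the scatter), is a different exchange and bears on this one only loosely. It offers no ground for a large shift, so nothing beyond the scatter is expected, and the expected step is a 1.5-fold lower number from compound 2 to compound 3 (0.17 log units; within the scatter). For compound 3 the estimate in this assay is 17000 nM, with an expected range of 6000 nM to 40000 nM.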

Compound 3, half-maximal inhibitory concentration: 16900 nM
Compound 3: the middle estimate sits 1.0-fold (0.00 log units) above what was measured; the range from low to high includes it.
By their numbers in this assay, from the lowest: compounds 1, 3 and 2 (each within the scatter of the next).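

With (2-hydroxy-2,3-dimethylbutyl)carbonyl on the oxygen on a saturated carbon, this assay shows a 1.5-fold lower number from compound 2 to compound 3 (0.18 log units; within the scatter) and a 1.0-fold higher number from compound 1 to compound 3 (0.02 log units; within the scatter) and so neither step leaves the scatter. Across the three compounds, this position therefore accepts a side chain with a carbonyl on the oxygen, as well as the 2-acetoxybutyl and 2-hydroxypropyl chains, with no separation in the numbers. No evidence at hand bears on this result.

On these data alone, whether a primary amine or a carboxylic acid on this side chain would move the number beyond the scatter remains open. The same holds for an aromatic ring or a much longer alkyl chain in this place.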